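Working notes: bromo to nitrooxy, compound 2 to compound 3

The source may report more compounds than this note shows. Statements on the series, on what has been measured and on what is new or still open speak of the compounds shown alone.

Measured compounds:
compound 1 `COc1ccc(/C=C/C(=O)c2ccc(NC(=O)CBr)cc2)cc1`: 42%
compound 2 `COc1ccc(/C=C/C(=O)c2ccc(NC(=O)C(C)Br)cc2)cc1`: 40%

In a functional assay on the whole organism (strain albino) for inhibition, with Rattus norvegicus as the target, read by paw edema, with stated times of 30 min and 2 h, at a dose of 100 mg/kg by the oral route (a higher number here means more inhibition at the dose given (going by the name of the read-out), a lower number less inhibition), compound 1 gives 42% and compound 2 gives 40%. Going by the values given here, the only measured step, a number 2 percentage points lower from compound 1 to compound 2 (within the scatter), goes with methyl in place of hydrogen on a saturated chain carbon bound to a bromine atom and a carbonyl carbon. Among the compounds with values here, compound 2 thus stands at one of only two numbers, and its gap to compound 1 is within the scatter, so neither compound is set apart from the other.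

Compound 3 `COc1ccc(/C=C/C(=O)c2ccc(NC(=O)C(C)O[N+](=O)[O-])cc2)cc1` differs from compound 2 by nitrooxy in place of bromo on a saturated chain carbon bound to a carbonyl carbon and a saturated chain carbon. Within the data shown here, no measured step touches the bromo or the nitrooxy group; the single step in hand concerns methyl for hydrogen and says nothing about this exchange. With nothing to point in either direction, the expected step is none beyond the scatter, no change at the digits printed from compound 2 to compound 3 (within the scatter), and the uncertainty is wide. For compound 3 the estimated value in this assay is 40%, with a range of 25% to 55%.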

Compound 3, a percentage reported as inhibition, in the whole organism at one dose (the size of the read-out at that dose, not a potency): 46%
For compound 3 the middle estimate is 6 percentage points below the measured one; measured number inside the range.
By their numbers in this assay, from the lowest: compounds 2, 1 and 3 (each within the scatter of the next).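

In this assay, nitrooxy in place of bromo on a saturated chain carbon bound to a carbonyl carbon and a saturated chain carbon gives a number 6 percentage points higher from compound 2 to compound 3 (within the scatter), so this position accepts 4 heavy atoms with 3 hydrogen-bond acceptors in place of 1 bromine without a step beyond the scatter. The wider exchange of bromomethyl for 1-(nitrooxy)ethyl on a carbonyl carbon reads the same way, with a number 4 percentage points higher from compound 1 to compound 3 (within the scatter), and compound 3 at 46% shows that a bromine atom on this chain is not required for a read-out of this size at this dose. No measurement on hand explains this result.

Going by these compounds, with all three compounds within the scatter of one another, no group at this position is yet set apart, and it remains open how far the inhibition depends on the group on this carbon at all. Also open, on these data alone, is how a dimethylamino group, a hydroxyl or a carboxylic acid in place of the nitrooxy would read, or a longer chain than 1-(nitrooxy)ethyl.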